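The source may report more compounds than this note shows. Statements on the series, on what has been measured and on what is new or still open speak of the compounds shown alone.

Compound 1 `COc1cc2cc(C#N)ccc2c(OC)c1Oc1cc(NC(C)C)nc(Nc2ccc(C#N)cc2)n1` stands at the assay limit in an ADME assay on MT4 cells (Homo sapiens) for cytotoxicity, read by MTT assay, with a stated time of 5 days (a lower number here means that less compound is tolerated, a higher number that more compound is tolerated), where compound 1 records > 125000 nM rather than a number. Compound 2 `COc1cc2cc(C#N)ccc2c(OC)c1Oc1cc(NCC(O)CO)nc(Nc2ccc(C#N)cc2)n1` gives 29500 nM in this assay. For the measured compounds named here, the one measured step that bears on the next compound is an at least 4.2-fold lower number from compound 1 to compound 2 (0.62 log units; beyond the scatter), a hydroxyl-bearing chain entering where isopropyl left. Compound 3 `COc1cc2cc(C#N)ccc2c(OC)c1Oc1cc(NCCCCO)nc(Nc2ccc(C#N)cc2)n1` differs from compound 1 by 4-hydroxybutyl in place of isopropyl on a nitrogen on an aromatic ring. Because compound 1 sits at the limit of > 125000 nM in this assay, at which 1 of the 2 values shown sits, a lower number is expected for compound 3, of roughly the size of that step. Compound 3 is therefore expected to give 50000 nM, between 18000 nM and 140000 nM, an estimated step of an at least 2.5-fold lower number from compound 1 to compound 3 (0.39 log units; beyond the scatter).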

Compound 3, half-maximal cytotoxic concentration: 39100 nM
Beside the measured number, compound 3's estimate is 1.3-fold (0.11 log units) above it, and the stated range covers the measured number.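

On the nitrogen on an aromatic ring, 4-hydroxybutyl in place of isopropyl brings an at least 3.1-fold lower number from compound 1 to compound 3 (0.50 log units; beyond the scatter) in this assay, so a second hydroxyl-bearing chain goes the same way as 2,3-dihydroxypropyl. The two hydroxyl-bearing chains are not told apart, with a 1.3-fold higher number from compound 2 to compound 3 (0.12 log units; within the scatter). Compound 1 records only a limit, which leaves the full size of the step unfixed: the limit of > 125000 nM in this assay, at which 1 of the 3 values shown sits.

The compounds shown leave open whether the hydroxyl or the chain itself goes with the change, which a plain butyl chain would address. Going by these compounds, how a chain carrying an amine or a carboxylic acid would read in this assay also stays open.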